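The source may report more compounds than this note shows. Statements on the series, on what has been measured and on what is new or still open speak of the compounds shown alone.

Working notes on the series. The read-out throughout is a functional assay on CCRF-CEM cells (Homo sapiens) for inhibition; a higher number here means a weaker inhibitor, a lower number a stronger inhibitor. Compound 1 `CC(C)C(NC(=O)NO)C(=O)NC1CCCC1` is one of two compounds whose result in this assay is only a limit of the assay: compound 1 gives > 200000 nM. Compound 2 `CC(C)C(NC(=O)n1nnc2ccccc21)C(=O)NC1CCCC1` likewise returns a limit in this assay, > 200000 nM. Among the measured compounds shown here, compound 3 `CCC(C)C(NC(=O)n1nnc2ccccc21)C(=O)NC1CCCC1` is the one compound of the three that gives a number; in this assay compound 3 gives 116000 nM. The change from compound 2 to compound 3 is methyl in place of hydrogen on a saturated chain carbon, three bonds along the chain from an amide-type nitrogen and a carbonyl carbon, and it makes a step of an at least 1.7-fold lower number from compound 2 to compound 3 (0.23 log units; that floor lies within the scatter); the two compounds from which this reading comes sit against (the limit of > 200000 nM in this assay, at which 2 of the 3 values shown sit), so the size of the step is bounded only from one side. How the core of compound 1 differs from the core of compound 2 is not broken down here. Compound 4 `CCC(C)C(NC(=O)NO)C(=O)NC1CCCC1` is not yet measured in this assay; it differs from compound 1 by methyl in place of hydrogen on a saturated chain carbon, three bonds along the chain from an amide-type nitrogen and a carbonyl carbon, the same change word for word, at the same place, as that from compound 2 to compound 3. The step from compound 1 to compound 4 in this assay is expected to be a step that the limit leaves unreadable from compound 1 to compound 4, resting on compound 2 and compound 3 and on the limit of compound 1. Compound 4 is expected to give about 250000 nM, between 90000 nM and 700000 nM, with a fair chance that only a limit is reported.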

Compound 4, half-maximal inhibitory concentration: > 100000 nM
Compound 4: a limit, no number (the forecaster's own chance of this, stated with the estimate: 60%); the middle value lies beyond the limit too.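

Compound 1 and compound 4 both return only limits of the assay in this assay, and the step between them cannot be read. The compounds shown leave open whether methyl in place of hydrogen at this place changes the read-out on the core of compound 1, and where the actual values of compound 1 and compound 4 lie.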